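Trifluoromethyl on the Propoxy Chain of Compound 1

This account rests on a few compounds, and the source may have more. Where it says the series, first, only, none or still open, it means among the compounds named here.

Compound 2, `CCOc1cc(CN(C)C(=O)c2c(OCCCC3CCN(C(=O)OC(C)(C)C)CC3)c3ccccc3n(C)c2=O)cc(OCC)c1`: 51 nM
Compound 3, `CN(Cc1cc(C(F)(F)F)cc(C(F)(F)F)c1)C(=O)c1c(OCCCC2CCN(C(=O)OC(C)(C)C)CC2)c2ccccc2n(C)c1=O`: 7.7 nM
Compound 1, `CCCOc1c(C(=O)N(C)Cc2cc(C(F)(F)F)cc(C(F)(F)F)c2)c(=O)n(C)c2ccccc12`: no result reported

In an assay for inhibition of phosphatidylcholine:ceramide cholinephosphotransferase 2 (Mus musculus), read by mass spectrometry, with stated times of 60 min and 30 min (on this read-out higher numbers stand for weaker inhibition and lower numbers for stronger inhibition), compound 3 gives 7.7 nM, and compound 2 gives 51 nM; the two differ in the benzyl substituents and share the rest of the core. Compound 1 stands apart: in this assay compound 1 is recorded as "not determined" (no result reported), so no number for it can anchor the step. Compound 4, `CN(Cc1cc(C(F)(F)F)cc(C(F)(F)F)c1)C(=O)c1c(OCCCC(F)(F)F)c2ccccc2n(C)c1=O`, arises from compound 1 by trifluoromethyl in place of hydrogen on a saturated chain carbon, three bonds along the chain from an oxygen on an aromatic ring. For the measured compounds named here, with no measured step between compounds that differ at this position alone, the size and direction of the change cannot be read from the data; the nearest guide is compound 3, which carries the same benzyl group on a longer chain and gives 7.7 nM in this assay. On that basis compound 4 is expected to fall near 30 nM, within the range 5 nM to 200 nM, a guess rather than a reading of any shown step.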

Compound 4, half-maximal inhibitory concentration: 240 nM
Beside the measured number, compound 4's estimate is 8.0-fold (0.90 log units) below it; the whole stated range lies below it.
By their numbers in this assay, from the lowest: compound 3; then compound 2; then compound 4.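

No step can be read from compound 4: in this assay compound 1 gives "not determined" (no result reported) and compound 4 gives 240 nM with no number to set against it. The compounds shown leave open what trifluoromethyl in place of hydrogen does on its own. No measurement here speaks to a cause.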